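The compounds below may be only part of what the source reports. "The series", "measured", "known", "first", "only" and "open" are said of these compounds alone.

Of the compounds shown here, three with the same side chain have been tested in an ADME assay on WS1 cells (Homo sapiens) for inhibition, with a stated time of 48 h; a higher number here means a weaker inhibitor, a lower number a stronger inhibitor. Compound 1 `COc1ccc2c(=O)cc(/C=C/[S+](C)[O-])oc2c1O` gives > 10000 nM, which is a limit of the assay and not a number. Compound 2 `COc1cc2oc(/C=C/[S+](C)[O-])cc(=O)c2cc1OC` gives > 10000 nM, also a limit. Going by the values given here, compound 3 `C[S+]([O-])/C=C/c1cc(=O)c2ccccc2o1`, which carries no methoxy group, gives 9000 nM, the only actual number in the set.

Compound 4 `COc1ccc2c(=O)cc(/C=C/[S+](C)[O-])oc2c1` is compound 3 with methoxy in place of hydrogen on an aromatic carbon. The new group sits on a six-membered aromatic ring of carbon only, meta to a fused ring and para to a fused ring.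

Among the compounds with values here, no measured pair isolates this change, so the evidence is indirect. Compound 1 and compound 2 both bear methoxy, and they share (the limit of > 10000 nM in this assay, at which 2 of the 3 values shown sit). A small move towards weaker inhibition in this assay is therefore expected, not far beyond the scatter, and compound 4 may well report only a limit. The expected step is a 1.3-fold higher number from compound 3 to compound 4 (0.12 log units; within the scatter). Compound 4 is estimated at 12000 nM, with an expected range of 6000 nM to 25000 nM.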

Compound 4, half-maximal inhibitory concentration: 9000 nM
The estimate for compound 4 lay 1.3-fold (0.12 log units) above the measured number, within the range that was stated.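

Putting methoxy on this aromatic carbon, meta to a fused ring and para to a fused ring, gives no change at the digits printed from compound 3 to compound 4 (within the scatter) in this assay, so this change on its own leaves the number where it was. Read from the other side, hydrogen in place of methoxy gives an at least 1.1-fold lower number from compound 2 to compound 4 (0.04 log units; that floor lies within the scatter) and hydrogen in place of hydroxy gives an at least 1.1-fold lower number from compound 1 to compound 4 (0.04 log units; that floor lies within the scatter), and neither floor goes beyond the scatter. Compound 1 and compound 2 each stand at a limit and not at a number, so these two steps give floors only: the limit of > 10000 nM in this assay, at which 2 of the 4 values shown sit.

The compounds shown leave open whether a different group on this carbon, such as an amine or a carboxylic acid, would move the number. They also leave open how far compound 1 and compound 2 truly lie from compound 4.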